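The source may report more compounds than this note shows. Statements on the series, on what has been measured and on what is new or still open speak of the compounds shown alone.

Compound 1 `CCC(=O)N(c1cccc(Br)c1)C1CCCC1N(C)C` gives 0.1 mg/kg in a functional assay on the whole organism for antagonist activity, with Mus musculus as the target; on this read-out higher numbers stand for an effect only at larger amounts of compound and lower numbers for an effect already at smaller amounts. Compound 3 `CCC(=O)N(c1cccc(C(F)(F)F)c1)C1CCCC1N(C)C` differs from compound 1 by trifluoromethyl in place of bromo on an aromatic carbon; in this assay compound 3 gives 0.2 mg/kg, a step of a 2.0-fold higher number from compound 1 to compound 3 (0.30 log units; within the scatter). Compound 2 `CCC(=O)N(c1ccc(Br)cc1)C1CCCC1N(C)C` is built from the same atoms as compound 1, joined differently; the difference between the two cores is not broken down here. In this assay compound 2 gives 3 mg/kg, the highest number of the three, its gaps to compound 1 and to compound 3 both lying beyond the scatter. Compound 4 `CCC(=O)N(c1ccc(C(F)(F)F)cc1)C1CCCC1N(C)C` is not yet measured; it differs from compound 2 by trifluoromethyl in place of bromo on an aromatic carbon. Among the compounds with values here, this is the same kind of change as the one between compound 1 and compound 3, though the place is not identical: in the earlier pair the group sits meta to a large group, here para to a large group. In this assay, within the data shown here, the expected step is a 1.7-fold higher number from compound 2 to compound 4 (0.22 log units; within the scatter), set beside the earlier one because the only measured instance of this change is a 2.0-fold higher number from compound 1 to compound 3 (0.30 log units; within the scatter). Compound 4 is accordingly expected to give about 5 mg/kg, within a range from 1.5 mg/kg to 15 mg/kg.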

Compound 4, dose for half-maximal effect: 25 mg/kg
Compound 4: the middle estimate sits 5.0-fold (0.70 log units) below what was measured, and the stated range ends below it.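

In this assay, trifluoromethyl in place of bromo on an aromatic carbon, para to a large group, gives an 8.3-fold higher number from compound 2 to compound 4 (0.92 log units; beyond the scatter). Within the data shown here, the size of this change therefore does not carry over unchanged from the core of compound 1 to the core of compound 2: the same change on two cores in this assay, a 2.0-fold higher number (0.30 log units; within the scatter) from compound 1 to compound 3 and an 8.3-fold higher number (0.92 log units; beyond the scatter) from compound 2 to compound 4, 4.2-fold (0.62 log units) apart, beyond the scatter of two such steps With only two pairs, the notes cannot say whether the gap follows from where the group sits or from some other difference between the cores, and they give no rule for how the change would behave on any further core.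

Still open, on these data alone, is whether a smaller group such as fluoro or chloro, or a nitrile or methoxy group, in the place of bromo would show the same dependence on the core. Also open, as far as these compounds go, is how far these steps hold once the dimethylamino group gives way to a primary amine or the chain on the carbonyl is lengthened.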